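The source may hold more compounds than are shown below. What is called first, only, known or untested is meant among the compounds shown, and "the series" means these compounds.

Working notes on the thioamide-to-dithiolethione series. Compound 1 `NC(=S)c1ccc(OC(=O)c2cccnc2)cc1` is the starting point; in an ADME assay for pharmacokinetics, in phosphate buffer, tested at 60 uM (on this read-out higher numbers stand for a longer-lived compound and lower numbers for a shorter-lived compound), compound 1 gives 0.035 h. Compound 2 `O=C(Oc1ccc(-c2cc(=S)ss2)cc1)c1cccnc1` differs from it by a group of 6 heavy atoms (3 carbon, 3 sulfur; one five-membered aromatic ring with 2 hetero atoms) in place of a group of 3 heavy atoms (1 carbon, 1 nitrogen, 1 sulfur; no ring), on an aromatic carbon, and in this assay compound 2 gives 0.055 h, so the step is a 1.6-fold higher number from compound 1 to compound 2 (0.20 log units; within the scatter). Compound 3 `CC(C)(Oc1ccc(Cl)cc1)C(=O)Oc1ccc(C(N)=S)cc1` sits on a different core; how the two cores differ is not broken down here. In this assay compound 3 gives 0.0933 h, which stands beyond the scatter only against compound 1. Compound 4 `CC(C)(Oc1ccc(Cl)cc1)C(=O)Oc1ccc(-c2cc(=S)ss2)cc1` has not been measured. It differs from compound 3 by a group of 6 heavy atoms (3 carbon, 3 sulfur; one five-membered aromatic ring with 2 hetero atoms) in place of a group of 3 heavy atoms (1 carbon, 1 nitrogen, 1 sulfur; no ring), on an aromatic carbon. This is the same kind of change as that from compound 1 to compound 2. Going by the values given here, for compound 4 the expected step is a 1.5-fold higher number from compound 3 to compound 4 (0.18 log units; within the scatter), set beside the earlier one because a 1.6-fold higher number from compound 1 to compound 2 (0.20 log units; within the scatter) is the single measured instance of this change and lies within the scatter. The estimate for compound 4 in this assay is 0.14 h, expected to fall between 0.06 h and 0.35 h.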

Compound 4, half-life: 0.07 h
The estimate for compound 4 lay 2.0-fold (0.30 log units) above the measured number; the measured number falls inside the stated range.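

On the core of compound 3, the group of six heavy atoms in place of the group of three heavy atoms gives a 1.3-fold lower number from compound 3 to compound 4 (0.12 log units; within the scatter). Set beside the earlier instance of this change in this assay, the two steps do not differ beyond what two such steps can show: the same change on two cores in this assay, a 1.6-fold higher number (0.20 log units; within the scatter) from compound 1 to compound 2 and a 1.3-fold lower number (0.12 log units; within the scatter) from compound 3 to compound 4, 2.1-fold (0.32 log units) apart, within the scatter of two such steps. On both cores the change therefore stays within the scatter, and the two steps give no reliable direction, but this does not show that the change has no effect on half-life, and two cores are too few to show that it would stay this small on a third.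

All four compounds shown are esters, leaving open whether the step stays this small when an amide takes the place of the ester link, or when the acid part carries an amine, a carboxylic acid or a longer chain. Also open, from the compounds shown here alone, is how a nitrile would compare with either group at the same place.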